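A few compounds are considered here, and "the series" means these few. Any claim that something is new, unique, unknown or untested is made for them only; others in the source may bear on it.

Measured compounds in an assay on microsomes from intestine for inhibition of acyl-CoA:cholesterol acyltransferase (Oryctolagus cuniculus); on this read-out higher numbers stand for weaker inhibition and lower numbers for stronger inhibition:

compound 1, `CSc1cc(C)nc(SC)c1NC(=O)N(Cc1ccccc1)Cc1cccc(-c2ccn(C)n2)c1`: 73 nM
compound 2, `CSc1cc(C)nc(SC)c1NC(=O)N(Cc1ccccc1)Cc1cccc(-c2ccnn2C)c1`: 28 nM
compound 3, `Cc1cc(C)c(NC(=O)N(Cc2cccc(-c3ccn(C)n3)c2)C2CCCCCC2)c(C)c1`: 42 nM

Compound 1 and compound 2 share one core and differ in a single place: 1-methyl-1H-pyrazol-5-yl in place of 1-methyl-1H-pyrazol-3-yl on an aromatic carbon. This change gives a 2.6-fold lower number from compound 1 to compound 2 (0.42 log units; beyond the scatter), so swapping the point at which the methylated pyrazole is attached moves the number in this assay by a modest but real amount.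

Compound 3 carries a different core. How its core differs from that of compound 1 is not broken down here. Its value in this assay lies within the usual scatter of both compound 1 and compound 2, so nothing can be said about an order among those three.

Compound 4, `Cc1cc(C)c(NC(=O)N(Cc2cccc(-c3ccnn3C)c2)C2CCCCCC2)c(C)c1`, is not yet measured. It relates to compound 3 exactly as compound 2 relates to compound 1: 1-methyl-1H-pyrazol-5-yl in place of 1-methyl-1H-pyrazol-3-yl on an aromatic carbon. The two place descriptions agree word for word. This is the same change made on a second core.

For the measured compounds named here, the expectation for compound 4 rests on the one comparable example. Since the same change produced a 2.6-fold lower number from compound 1 to compound 2 (0.42 log units; beyond the scatter), the step from compound 3 to compound 4 is expected to be a 2.1-fold lower number from compound 3 to compound 4 (0.32 log units; beyond the scatter), allowing that a second core need not respond identically. Compound 4 is therefore estimated at 20 nM, with a likely range from 10 nM to 45 nM.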

Compound 4, half-maximal inhibitory concentration: 35 nM
The estimate for compound 4 lay 1.8-fold (0.24 log units) below the measured number; the range from low to high includes it.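

On the second core, moving the attachment point of the methylated pyrazole gives a 1.2-fold lower number from compound 3 to compound 4 (0.08 log units; within the scatter) in this assay, so on this core the swap from 1-methyl-1H-pyrazol-3-yl to 1-methyl-1H-pyrazol-5-yl shows no real change. Set side by side, the two steps cannot be told apart: the same change on two cores in this assay, a 2.6-fold lower number (0.42 log units; beyond the scatter) from compound 1 to compound 2 and a 1.2-fold lower number (0.08 log units; within the scatter) from compound 3 to compound 4, 2.2-fold (0.34 log units) apart, within the scatter of two such steps. The two cores therefore cannot be said to respond differently, yet the real change on the first core is not shown to carry over to the second, and two pairs are too few to give a rule for the series.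

The compounds shown leave open how this swap behaves on any further core, which a third matched pair would help to settle. They also leave open what happens when the pyrazole carries an ethyl group instead of the methyl on its nitrogen, or when a carboxylic acid or an amine takes its place on the ring.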